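A few compounds are considered here, and "the series" means these few. Any claim that something is new, unique, unknown or untested is made for them only; others in the source may bear on it.

Measured compounds in a toxicity assay on Vero cells (Chlorocebus sabaeus) for cytotoxicity; on this read-out higher numbers stand for lower toxicity in this test and lower numbers for higher toxicity in this test:
Compound 1 `COc1nc(C2CCOCC2)ccc1[C@@H](c1ccccc1)[C@@](O)(CCN(C)C)c1cccc2ccccc12` gives a limit of > 50 ug/mL, not a number.
Compound 2 `COc1nc(-c2ccc(Cl)cc2)ccc1[C@@H](c1ccccc1)[C@@](O)(CCN(C)C)c1cccc2ccccc12` gives a limit of > 50 ug/mL, not a number.
Compound 3 `COc1nc(-c2cccc(Cl)c2)ccc1[C@@H](c1ccccc1)[C@@](O)(CCN(C)C)c1cccc2ccccc12` gives a limit of > 50 ug/mL, not a number.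

Compound 1 therefore stands only at a limit in this assay, and the two further values shown are limits as well. All three measured compounds sit at the limit of > 50 ug/mL in this assay, at which 3 of the 3 values shown sit, so none of them can be placed relative to another.

The step to compound 4 `COc1nc(-c2ccc(C(F)(F)F)cc2)ccc1[C@@H](c1ccccc1)[C@@](O)(CCN(C)C)c1cccc2ccccc12` replaces the group on the core of compound 1: 4-(trifluoromethyl)phenyl in place of oxan-4-yl on an aromatic carbon. The measured steps that bear on this change are a step that the two limits leave unreadable from compound 1 to compound 2, a step that the two limits leave unreadable from compound 1 to compound 3 and a step that the two limits leave unreadable from compound 2 to compound 3. Each of these exchanges the oxan-4-yl for an aryl group, or one aryl group for another, at the same place, and none of them produced a readable size, because both ends of every step sit at the limit of > 50 ug/mL in this assay, at which 3 of the 3 values shown sit.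

With three limits and no readable step, no change beyond the scatter is expected in this assay for the step from compound 1 to compound 4, and the estimated step is a number no higher from compound 1 to compound 4 (the limit leaves the size open). Compound 4 is accordingly expected to give 50 ug/mL in this assay, within a range from 25 ug/mL to 100 ug/mL, most likely reported again only as a limit.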

Compound 4, half-maximal cytotoxic concentration: > 50 ug/mL
Compound 4: no number, only a limit; the forecaster's own chance of this, stated with the estimate: 80%; the middle value lies on the limit itself.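

In this assay compound 4 gives > 50 ug/mL, which is a limit and not a number. Its steps from compound 1, compound 2 and compound 3 therefore cannot be read, because all four compounds share one limit: the limit of > 50 ug/mL in this assay, at which 4 of the 4 values shown sit.

The compounds shown leave open whether exchanging the group at this place changes the read-out at all.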